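A few compounds are considered here, and "the series" means these few. Any claim that something is new, unique, unknown or untested is made for them only; others in the source may bear on it.

In a functional assay on HFF cells (Homo sapiens) for cytotoxicity (a lower number here means a stronger inhibitor, a higher number a weaker inhibitor), compound 1 (`O=C1/C(=C/c2ccc(Cl)c(F)c2)SC(=S)N1NS(=O)(=O)c1ccccc1`) gives > 100000 nM as its reading, and this is a limit of the assay, not a number. Compound 2 (`O=C1/C(=C/c2cc(F)ccc2F)SC(=S)N1NS(=O)(=O)c1ccccc1`) gives > 100000 nM as its reading, which is likewise a limit. Compound 2 thus stands at the limit of > 100000 nM in this assay, at which 2 of the 2 values shown sit, and has no number of its own.

The next compound, compound 3 (`O=C1/C(=C/c2ccc(F)c(F)c2F)SC(=S)N1NS(=O)(=O)c1ccccc1`), keeps the shared core and changes a single group: 2,3,4-trifluorophenyl in place of 2,5-difluorophenyl on a double-bonded chain carbon bound to a double-bonded ring carbon is the whole difference. For the measured compounds named here, the one measured change at this place is a step that the two limits leave unreadable from compound 1 to compound 2 and gives no size to work from, yet neither compound left the limit. No step beyond the scatter is therefore expected in this assay, in either direction. The estimated change is a number no higher from compound 2 to compound 3 (the limit leaves the size open) for this swap. For compound 3 the estimate is 100000 nM as the expected value (expected range 40000 nM to 200000 nM).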

Compound 3, half-maximal inhibitory concentration: > 100000 nM
Compound 3: a limit, no number; the forecaster's own chance of this, stated with the estimate: 85%; the middle value lies on the limit itself.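

The reading of compound 3 is also a limit of the assay, not a number: the limit of > 100000 nM in this assay, at which 3 of the 3 values shown sit.

No step can be read among compound 1, compound 2 and compound 3. Going by these compounds, it stays open whether these aryl groups differ at all in this assay, and what number any of the three compounds would give.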